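The compounds below may be only part of what the source reports. "The series", "measured", "known", "first", "only" and "open" are said of these compounds alone.

Working notes on the series. Compound 1 `O=c1[nH]c(=O)n([C@H]2C[C@H](O)[C@@H](CO)O2)cc1-c1cn(-c2ccccc2)nn1` carries the unsubstituted phenyl and stands highest of the three numbers in an ADME assay on CCRF-CEM cells (Homo sapiens) for cytotoxicity, read by cell counting, with a stated time of 3 days (a higher number here means a weaker inhibitor, a lower number a stronger inhibitor), giving 75000 nM. Compound 2 `CC(C)c1ccc(-n2cc(-c3cn([C@H]4C[C@H](O)[C@@H](CO)O4)c(=O)[nH]c3=O)nn2)cc1` gives 22000 nM and compound 3 `O=c1[nH]c(=O)n([C@H]2C[C@H](O)[C@@H](CO)O2)cc1-c1cn(-c2ccc(Cl)cc2)nn1` gives 13000 nM in this assay; the change from compound 2 to compound 3 is a 1.7-fold lower number from compound 2 to compound 3 (0.23 log units; within the scatter). The step to compound 4 `O=c1[nH]c(=O)n([C@H]2C[C@H](O)[C@@H](CO)O2)cc1-c1cn(-c2ccc(Br)cc2)nn1` is bromo in place of hydrogen on an aromatic carbon. The measured steps that bear on it are a 3.4-fold lower number from compound 1 to compound 2 (0.53 log units; beyond the scatter) and a 5.8-fold lower number from compound 1 to compound 3 (0.76 log units; beyond the scatter), both modest and beyond the scatter, pointing toward a lower number for a halogen on that carbon. By analogy with the chloro step the expected step is a 6.3-fold lower number from compound 1 to compound 4 (0.80 log units; beyond the scatter), lower. Compound 4 is therefore estimated at 12000 nM, with a range from 5000 nM to 30000 nM.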

Compound 4, half-maximal inhibitory concentration: 1800 nM
Compound 4: middle estimate off by 6.7-fold (0.82 log units), on the high side; the measured number lies below the stated range.
By their numbers in this assay, from the lowest: compound 4; then compounds 3 and 2 (each within the scatter of the next); then compound 1.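

At the carbon para to a large group, the two halogens part clearly in this assay: the step of a 7.2-fold lower number from compound 3 to compound 4 (0.86 log units; beyond the scatter) separates bromo from chloro, and the step of a 42-fold lower number from compound 1 to compound 4 (1.62 log units; beyond the scatter) is large where chloro's was modest. Bromo also separates from isopropyl, with a 12-fold lower number from compound 2 to compound 4 (1.09 log units; beyond the scatter) as the step, although chloro and isopropyl lie within the scatter of each other. Nothing available here accounts for the bromo result. Open, going by these compounds, is how iodo, fluoro, an amine or a carboxylic acid would read on this carbon.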